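Working notes: one chloro removed from compound 2

The source may report more compounds than this note shows. Statements on the series, on what has been measured and on what is new or still open speak of the compounds shown alone.

Measured so far:
compound 1 `ClCc1cccc(Cn2cnc3c(Cl)ncnc32)c1`, 8910 nM
compound 2 `ClCc1ccc(Cn2cnc3nc(Cl)nc(Cl)c32)cc1`, 15500 nM

Among the measured compounds shown here, in a functional assay on NCI-H226 cells (Homo sapiens) for cytotoxicity, read by sulforhodamine B assay, with a stated time of 48 h (a higher number here means that more compound is tolerated, a lower number that less compound is tolerated), compound 2 gives 15500 nM, the higher of the two numbers so far; compound 1 at 8910 nM sits close, and the gap between them is within the usual scatter, so no order can be read from it. Compound 3 `ClCc1ccc(Cn2cnc3ncnc(Cl)c32)cc1` differs from compound 2 by hydrogen in place of chloro on an aromatic carbon; in words, hydrogen in place of chloro on an aromatic carbon. For the measured compounds named here, no step between measured compounds isolates this change, and the two compounds measured so far give no lead on its direction. The expected step in this assay is a 1.4-fold lower number from compound 2 to compound 3 (0.15 log units; within the scatter), no further than the scatter carries and in no firm direction. Compound 3 is estimated at 11000 nM, with a range from 4500 nM to 27000 nM expected to cover most repeats.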

Compound 3, concentration lethal to 50% of the cells: 37200 nM
Beside the measured number, compound 3's estimate is 3.4-fold (0.53 log units) below it; measured number outside the range, above it.
By their numbers in this assay, from the lowest: compounds 1 and 2 (each within the scatter of the next); then compound 3.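

In this assay, hydrogen in place of chloro on an aromatic carbon between two ring nitrogen atoms gives a 2.4-fold higher number from compound 2 to compound 3 (0.38 log units; beyond the scatter), a modest step, and with the chloro gone more compound is tolerated. Among the compounds shown here, this is the first step that isolates a single change, and it shows that this position is not indifferent to its substituent; the other chloro is common to compound 2 and compound 3, so the step belongs to this one place. Nothing on hand bears on why the number moves this way.

Still open, on these data alone, is whether an amine or a methoxy group at this position would follow hydrogen or chloro. Also open, as far as these compounds go, is whether the same change at the remaining chloro would give a step of similar direction.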